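The source may hold more compounds than are shown below. What is called first, only, known or untested is meant among the compounds shown, and "the series" means these compounds.

Measured compounds:
compound 1 `CN(C(=O)NC(=O)c1ccc(Cl)cc1Cl)c1nc(C(F)(F)F)c(C(=O)N/N=C/c2cccc(C(F)(F)F)c2)s1` — 6.11 ug/mL
compound 2 `CN(C(=O)NC(=O)c1ccc(Cl)cc1Cl)c1nc(C(F)(F)F)c(C(=O)N/N=C/c2ccc(C(F)(F)F)cc2)s1` — 3.08 ug/mL
compound 3 `CN(C(=O)NC(=O)c1ccc(Cl)cc1Cl)c1nc(C(F)(F)F)c(C(=O)N/N=C/c2cc(C(F)(F)F)cc(C(F)(F)F)c2)s1` — a limit, > 100 ug/mL

In a functional assay on BCG823 cells (Homo sapiens) for inhibition, read by MTT assay, with a stated time of 72 h (on this read-out lower numbers stand for stronger inhibition and higher numbers for weaker inhibition), compound 1 gives 6.11 ug/mL. Compound 2 sits within the scatter of it, a 2.0-fold lower number from compound 1 to compound 2 (0.30 log units; within the scatter). Compound 3 gives only a limit of this assay, > 100 ug/mL; the step from compound 1 was large, an at least 16-fold higher number from compound 1 to compound 3 (1.21 log units; beyond the scatter), and both numbers of that step rest on (the limit of > 100 ug/mL in this assay, at which 1 of the 3 values shown sits).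

Compound 4 `CN(C(=O)NC(=O)c1ccc(C(F)(F)F)cc1)c1nc(C(F)(F)F)c(C(=O)N/N=C/c2cccc(C(F)(F)F)c2)s1` differs from compound 1 in one place: 4-(trifluoromethyl)phenyl in place of 2,4-dichlorophenyl on a carbonyl carbon. Neither measured step touches this part of the shared core. The step from compound 1 to compound 2 moved a trifluoromethyl around the phenyl on the carbon with a double bond to nitrogen and stayed within the scatter; the step from compound 1 to compound 3 added a second trifluoromethyl on that same side and was large. Nothing measured speaks to the aroyl group on the carbonyl carbon, so no direction is expected beyond the scatter, with wide uncertainty. Compound 4 is therefore expected to give about 6 ug/mL, between 2 ug/mL and 25 ug/mL, a step of a 1.0-fold lower number from compound 1 to compound 4 (0.01 log units; within the scatter).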

Compound 4, half-maximal inhibitory concentration: 1.84 ug/mL
Estimate against measurement, compound 4: 3.3-fold (0.51 log units) above; the measured number lies below the stated range.
By their numbers in this assay, from the lowest: compounds 4, 2 and 1 (each within the scatter of the next, the first and the last beyond it). At a limit, above all of these: compound 3.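

In this assay, putting 4-(trifluoromethyl)phenyl in place of 2,4-dichlorophenyl on the carbonyl carbon gave a 3.3-fold lower number from compound 1 to compound 4 (0.52 log units; beyond the scatter). This shows that the read-out responds to the group on this carbonyl carbon, whereas compounds 1, 2 and 3 all carry 2,4-dichlorophenyl there and differ only in the aryl group on the carbon with a double bond to nitrogen. Nothing measured here accounts for this step.

The change removes both chlorine atoms and brings in trifluoromethyl in a single step, and the compounds shown do not separate these two parts. Also open, on these data alone, is what a methoxy group, an amine or a carboxylic acid on this phenyl would give, and whether the same exchange would lower the number when made on compound 2.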